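A few compounds are considered here, and "the series" means these few. Any claim that something is new, unique, unknown or untested is made for them only; others in the source may bear on it.

Measured compounds:
compound 1 `O=C(Nc1cc(-c2ccccc2)nn1-c1ccccc1)c1ccsc1` — in an assay on CHO cells with metabotropic glutamate receptor 5 (Homo sapiens) as the target (a higher number here means that more compound is needed for the effect, a lower number that less compound is needed), compound 1 gives 1800 nM
compound 2 `O=C(Nc1cc(-c2ccccc2)nn1-c1ccccc1)c1ccccc1O` — in this assay compound 2 reaches only the limit > 10000 nM
compound 3 `O=C(Nc1cc(-c2ccccc2)nn1-c1ccccc1)c1cnccn1` — in this assay compound 3 gives 200 nM

Among these three, compound 3 stands lowest of the two numbers; its nearest neighbour is compound 1, and the step of a 9.0-fold lower number from compound 1 to compound 3 (0.95 log units; beyond the scatter) lies beyond the scatter. The value of compound 2 is a limit of the assay and not a number (the limit of > 10000 nM in this assay, at which 1 of the 3 values shown sits); the step of an at least 50-fold lower number from compound 2 to compound 3 (1.69 log units; beyond the scatter) therefore only sets a floor on the gap.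

Compound 4 `O=C(Nc1cc(-c2ccccc2)nn1-c1ccccc1)c1cccc(Cl)c1` has not yet been measured. It differs from compound 3 by 3-chlorophenyl in place of pyrazin-2-yl on a carbonyl carbon. Within the data shown here, two measured steps bear on this change, both arriving at the pyrazin-2-yl carbonyl of compound 3 from another aryl carbonyl: from thiophen-3-yl, a 9.0-fold lower number from compound 1 to compound 3 (0.95 log units; beyond the scatter), and from 2-hydroxyphenyl, an at least 50-fold lower number from compound 2 to compound 3 (1.69 log units; beyond the scatter). Leaving the pyrazin-2-yl group for a carbon-only ring, then, has so far meant a higher number, modest in one case and at least large in the other. The account here expects a higher number for compound 4 in this assay, with a step estimated at a 7.5-fold higher number from compound 3 to compound 4 (0.88 log units; beyond the scatter). The value expected for compound 4 in this assay is 1500 nM, between 400 nM and 8000 nM.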

Compound 4, half-maximal effective concentration: 40 nM
For compound 4 the middle estimate is 38-fold (1.57 log units) above the measured one; the whole stated range lies above it.
By their numbers in this assay, from the lowest: compound 4; then compound 3; then compound 1. At a limit, above all of these: compound 2.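

In this assay the pyrazin-2-yl group is not the lowest point at this carbonyl carbon, since 3-chlorophenyl in its place gives a further drop (a 5.0-fold lower number from compound 3 to compound 4 (0.70 log units; beyond the scatter)), and compound 4 thus goes against the pattern of compounds 1 and 2, where both groups other than pyrazin-2-yl stood higher than compound 3. With the amide and the shared core unchanged, the choice of ring at this place alone now spans a wide range, as the step from the thiophen-3-yl group shows (a 45-fold lower number from compound 1 to compound 4 (1.65 log units; beyond the scatter)), and the step from the 2-hydroxyphenyl group is wider still (an at least 250-fold lower number from compound 2 to compound 4 (2.39 log units; beyond the scatter)). That last step only sets a floor, as compound 2 stands at a limit and not at a number: the limit of > 10000 nM in this assay, at which 1 of the 4 values shown sits.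

On these data alone, what a plain phenyl group, or a nitrile or a methoxy group in place of the chlorine, would do on this carbonyl carbon stays open. As far as these compounds go, all four compounds share one core, so it also stays open whether this order of the rings would hold with other groups on that core, and the values themselves do not tell why the rings rank as they do.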